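This account rests on a few compounds, and the source may have more. Where it says the series, first, only, none or still open, it means among the compounds named here.

Compound 1 `COc1cc2c(Oc3ccc(NC(=O)c4nn(-c5ccccc5)c(=O)cc4C)cc3F)ccnc2cc1OCCCN1CCCCC1`: 160 nM
Compound 2 `COc1cc2c(Oc3ccc(NC(=O)c4nn(-c5ccccc5C(F)(F)F)c(=O)cc4C)cc3F)ccnc2cc1OCCCN1CCCCC1`: 170 nM
Compound 3 `COc1cc2c(Oc3ccc(NC(=O)c4nn(-c5cccc(F)c5)c(=O)cc4C)cc3F)ccnc2cc1OCCCN1CCCCC1`: 290 nM

These three compounds share one core and differ only in the ring carried on the aromatic nitrogen. In a functional assay on HT-29 cells (Homo sapiens) for inhibition, read by MTT assay, with a stated time of 72 h (on this read-out lower numbers stand for stronger inhibition and higher numbers for weaker inhibition), compound 3 gives 290 nM, the highest of the three numbers, but the steps of a 1.8-fold higher number from compound 1 to compound 3 (0.26 log units; within the scatter) and a 1.7-fold higher number from compound 2 to compound 3 (0.23 log units; within the scatter) both stay within the scatter, so no order among them can be claimed.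

Compound 4 `COc1ccc(-n2nc(C(=O)Nc3ccc(Oc4ccnc5cc(OCCCN6CCCCC6)c(OC)cc45)c(F)c3)c(C)cc2=O)cc1` differs from compound 3 by 4-methoxyphenyl in place of 3-fluorophenyl on an aromatic nitrogen. Every step measured so far swaps a group on this same ring: a 1.1-fold higher number from compound 1 to compound 2 (0.03 log units; within the scatter), a 1.8-fold higher number from compound 1 to compound 3 (0.26 log units; within the scatter) and a 1.7-fold higher number from compound 2 to compound 3 (0.23 log units; within the scatter), none beyond the scatter. A step of similar size is therefore expected here, in no particular direction: compound 4 is expected to show a 1.3-fold lower number from compound 3 to compound 4 (0.12 log units; within the scatter) in this assay. The estimate for compound 4 is 220 nM, with a range from 100 nM to 480 nM.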

Compound 4, half-maximal inhibitory concentration: 3200 nM
For compound 4 the middle estimate is 15-fold (1.16 log units) below the measured one, outside the stated range (above it).
By their numbers in this assay, from the lowest: compounds 1, 2 and 3 (each within the scatter of the next); then compound 4.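

Within the data shown here, the ring on the aromatic nitrogen is less tolerant than the earlier compounds suggested: in this assay, adding methoxy to the phenyl gives a 20-fold higher number from compound 1 to compound 4 (1.30 log units; beyond the scatter). Among these compounds, the other two swaps agree, with an 11-fold higher number from compound 3 to compound 4 (1.04 log units; beyond the scatter) and a 19-fold higher number from compound 2 to compound 4 (1.27 log units; beyond the scatter), so these are the first steps here beyond the scatter. Nothing available explains this jump.

On these data alone, it remains open whether the higher number follows the methoxy group itself or its placement on the ring. As far as these compounds go, how a hydroxyl or an amine on this ring would behave also remains unknown.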